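Fluoro to chloro on the terminal phenyl of compound 1

The source may hold more compounds than are shown below. What is called first, only, known or untested is meant among the compounds shown, and "the series" means these compounds.

Compound 1 `N=C(N)c1ccc(-c2ccc(-c3ccc(F)cc3)s2)cc1` gives 1340 nM in a functional assay on KM12 cells (Homo sapiens) for inhibition, read by sulforhodamine B assay, with a stated time of 48 h (on this read-out lower numbers stand for stronger inhibition of growth and higher numbers for weaker inhibition of growth), the second highest of the three numbers. Compound 2 `COc1cc(OC)cc(-c2ccc(-c3ccc(C(=N)N)c(F)c3)s2)c1` gives 352 nM, and compound 3 `COc1cc(OC)cc(-c2ccc(-c3ccc(C(=N)N)cc3)s2)c1` gives 1840 nM; compound 3 lies within the scatter of compound 1, while compound 2 sits beyond it. Compound 4 `N=C(N)c1ccc(-c2ccc(-c3ccc(Cl)cc3)s2)cc1` differs from compound 1 by chloro in place of fluoro on an aromatic carbon. Going by the values given here, the one measured step, a 5.2-fold higher number from compound 2 to compound 3 (0.72 log units; beyond the scatter), concerns a fluoro on the other ring of a differently substituted core and does not speak to a halogen exchange; no measured pair bears directly on the change. Compound 4 is therefore expected to show no step beyond the scatter, a 1.1-fold lower number from compound 1 to compound 4 (0.05 log units; within the scatter). The estimate for compound 4 is 1200 nM, in the range 450 nM to 3200 nM.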

Compound 4, concentration for 50% growth inhibition: 196 nM
Beside the measured number, compound 4's estimate is 6.1-fold (0.79 log units) above it, outside the stated range (below it).
By their numbers in this assay, from the lowest: compounds 4 and 2 (each within the scatter of the next); then compounds 1 and 3 (each within the scatter of the next).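

In this assay, the change from 4-fluorophenyl to 4-chlorophenyl gives a 6.8-fold lower number from compound 1 to compound 4 (0.83 log units; beyond the scatter). The earlier compounds shown here offered no step at this position, para to a large group; this one shows that the identity of the halogen there matters for growth inhibition. Nothing available explains the difference.

Open, on these data alone, is how bromo, trifluoromethyl or nitrile would read at this position, and how the unsubstituted phenyl would compare. Also open, as far as these compounds go, is whether the fluoro on the other ring, as in compound 2, would add to the chloro of compound 4.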